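Butyl in place of tert-butyl: the step to compound 3

The source may report more compounds than this note shows. Statements on the series, on what has been measured and on what is new or still open speak of the compounds shown alone.

For the measured compounds named here, in a functional assay on the whole organism for inhibition, with Mythimna separata as the target, with a stated time of 5 days (on this read-out lower numbers stand for an effect already at smaller amounts and higher numbers for an effect only at larger amounts of compound), compound 2 `CC(C)(C)n1ncc(OCc2nnc(-c3ccc(Cl)cc3)o2)c(Cl)c1=O` gives 1.9 ug/mL, the only actual number so far. Compound 1 `CCCCn1ncc(OCc2nnc(-c3ccccc3)o2)c(Cl)c1=O` gives > 300 ug/mL, which is a limit of the assay and not a number. Compound 3 `CCCCn1ncc(OCc2nnc(-c3ccc(Cl)cc3)o2)c(Cl)c1=O` departs from compound 2 in one place: butyl in place of tert-butyl on an aromatic nitrogen. Going by the values given here, no measured step isolates this change, and the two measured compounds differ in more than one place, so its size remains open. Among the compounds with values here, a move to a higher number in this assay, beyond the scatter, is expected, and the only support is compound 1, which also carries butyl, at its limit of > 300 ug/mL. The estimated change is a 16-fold higher number from compound 2 to compound 3 (1.20 log units; beyond the scatter). For compound 3 the estimated value is 30 ug/mL, with an expected range of 4 ug/mL to 250 ug/mL.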

Compound 3, half-maximal effective concentration: 224 ug/mL
The estimate for compound 3 lay 7.5-fold (0.87 log units) below the measured number; low and high end bracket the measured number.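

In this assay butyl in place of tert-butyl on an aromatic nitrogen brings the large step of a 120-fold higher number from compound 2 to compound 3 (2.07 log units; beyond the scatter) and so gives the first isolated measure of a change at this position. The two compounds have the same atoms, and both groups have 4 carbon, so at this nitrogen the activity in this series follows how those carbons are joined and not their count. Chloro in place of hydrogen on an aromatic carbon brings an at least 1.3-fold lower number from compound 1 to compound 3 (0.12 log units; that floor lies within the scatter) and this step cannot be read in size, since compound 1 stands at a limit of the assay and not at a number: the limit of > 300 ug/mL in this assay, at which 1 of the 3 values shown sits.

Where a shorter or differently branched chain, such as ethyl or isopropyl, would fall relative to tert-butyl and butyl remains open. Also open, on these data alone, is what the chloro group contributes when tert-butyl sits on the nitrogen.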